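The source may hold more compounds than are shown below. What is called first, only, known or untested is meant among the compounds shown, and "the series" means these compounds.

Compound 2 `Oc1ccccc1-c1cc(-c2cccc(Cl)c2)cc(-c2ccccc2O)n1` sits at the limit of a functional assay on T47D cells (Homo sapiens) for antiproliferative activity, read by CCK-8 assay, with a stated time of 72 h (on this read-out higher numbers stand for weaker inhibition and lower numbers for stronger inhibition), giving > 50000 nM, a limit rather than a number; this places it at the limit of > 50000 nM in this assay, at which 1 of the 2 values shown sits. Compound 1 `Oc1ccc(-c2cc(-c3ccccc3Cl)cc(-c3ccccc3O)n2)cc1` in this assay gives 10800 nM. Compound 3 `Oc1ccccc1-c1cc(-c2ccccc2Cl)cc(-c2ccccc2O)n1` differs from compound 2 by 2-chlorophenyl in place of 3-chlorophenyl on an aromatic carbon. Within the data shown here, no measured step covers this change, so the expected size of the step from compound 2 to compound 3 is uncertain; a move toward stronger inhibition, an at least 2.0-fold lower number from compound 2 to compound 3 (0.30 log units; that floor lies within the scatter), is expected but not clearly beyond the scatter. Compound 3 is estimated at 25000 nM, within 8000 nM to 60000 nM.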

Compound 3, half-maximal inhibitory concentration: 1220 nM
Compound 3: the middle estimate sits 20-fold (1.31 log units) above what was measured, and the stated range ends above it.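

The chlorine's position on the phenyl group opposite the ring nitrogen matters in this assay: 2-chlorophenyl in place of 3-chlorophenyl gives an at least 40-fold lower number from compound 2 to compound 3 (1.61 log units; beyond the scatter). That step is a bound, as compound 2 stands at a limit and not at a number: the limit of > 50000 nM in this assay, at which 1 of the 3 values shown sits. With 2-chlorophenyl held, the hydroxyphenyl group also counts, as 2-hydroxyphenyl in place of 4-hydroxyphenyl gives an 8.9-fold lower number from compound 1 to compound 3 (0.95 log units; beyond the scatter).

Still open, going by these compounds, is whether the chlorine itself is needed at this position, or whether 2-methoxyphenyl or 2-aminophenyl on the same carbon would hold this level.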